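The source may hold more compounds than are shown below. What is called first, only, known or untested is meant among the compounds shown, and "the series" means these compounds.

The compounds share one core. Compound 1 `CN1CCc2nc(C#Cc3ccccc3)sc2C1` carries a methyl on the amine nitrogen in its ring, and compound 2 `CC1CC1C(=O)N1CCc2nc(C#Cc3ccccc3)sc2C1` carries a (2-methylcyclopropyl)carbonyl there instead. In an assay on HEK293 cells for negative allosteric modulation of metabotropic glutamate receptor 5 (Homo sapiens), read by FLIPR, with a stated time of 1 h (on this read-out higher numbers stand for weaker inhibition and lower numbers for stronger inhibition), compound 1 gives only a limit of the assay, > 10000 nM. In this assay compound 2 likewise gives only a limit, > 10000 nM. The step that the two limits leave unreadable from compound 1 to compound 2 therefore cannot be read, and compound 2 stands at the same limit as compound 1; both values sit at the limit of > 10000 nM in this assay, at which 2 of the 2 values shown sit.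

Compound 3 `O=C(C1CC12CCC2)N1CCc2nc(C#Cc3ccccc3)sc2C1` differs from compound 2 by a group of 6 heavy atoms (6 carbon; one three-membered non-aromatic ring of carbon only, one four-membered non-aromatic ring of carbon only) in place of a group of 4 heavy atoms (4 carbon; one three-membered non-aromatic ring of carbon only), on a carbonyl carbon. Within the data shown here, no measured step bears on this change, since the one step recorded is unreadable between two limits, and both measured compounds sit at the limit. With nothing showing inhibition in either neighbour, compound 3 is expected to remain at or near the limit, and the step of a number no higher from compound 2 to compound 3 (the limit leaves the size open) is expected to lie within the scatter. Compound 3 is estimated at 10000 nM, within 3000 nM to 30000 nM.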

Compound 3, half-maximal inhibitory concentration: > 10000 nM
Compound 3: only a limit was reported; the forecaster's own chance of this, stated with the estimate: 75%; the middle value lies on the limit itself.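

In this assay compound 3 also gives only a limit, > 10000 nM. The steps linking compound 3 with compound 1 and compound 2 therefore cannot be read, as all three stand at the same limit: the limit of > 10000 nM in this assay, at which 3 of the 3 values shown sit.

The compounds shown leave open whether any group on the amine nitrogen in the ring of the shared core gives a readable inhibition value.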